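Growth inhibition notes: methoxycarbonyl in place of nitro

A few compounds are considered here, and "the series" means these few. Any claim that something is new, unique, unknown or untested is made for them only; others in the source may bear on it.

Measured in a functional assay on MCF7 cells (Homo sapiens) for inhibition, read by MTT assay; on this read-out lower numbers stand for stronger inhibition of growth and higher numbers for weaker inhibition of growth:
- compound 1 `COc1cc2oc(-c3cccc(NC(=O)c4ccccc4Br)c3)cc(=O)c2c(OC)c1OC`: 55000 nM
- compound 2 `COc1cc2oc(-c3cccc(NC(=O)c4ccc(F)cc4)c3)cc(=O)c2c(OC)c1OC`: 14700 nM
- compound 3 `COc1cc2oc(-c3cccc(NC(=O)c4ccc([N+](=O)[O-])cc4)c3)cc(=O)c2c(OC)c1OC`: 20100 nM

Compound 3 stands at 20100 nM, in the middle ground of these three numbers. Its nearest neighbour is reached by a 1.4-fold higher number from compound 2 to compound 3 (0.14 log units; within the scatter). Its furthest is reached by a 2.7-fold lower number from compound 1 to compound 3 (0.44 log units; beyond the scatter).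

The next compound is compound 4 `COC(=O)c1ccc(C(=O)Nc2cccc(-c3cc(=O)c4c(OC)c(OC)c(OC)cc4o3)c2)cc1`, with methoxycarbonyl in place of nitro on an aromatic carbon, para to a large group: methoxycarbonyl in place of nitro on an aromatic carbon.

Going by the values given here, the closest precedent is the change at this same place, a 1.4-fold higher number from compound 2 to compound 3 (0.14 log units; within the scatter). The other two measured steps, a 3.7-fold lower number from compound 1 to compound 2 (0.57 log units; beyond the scatter) and a 2.7-fold lower number from compound 1 to compound 3 (0.44 log units; beyond the scatter), are modest, but both start from 2-bromophenyl and so involve a different placement of the group. They say little about a swap at the position held here. Among the compounds with values here, with only one measured change at this place, the evidence is thin, and nothing yet shows how methoxycarbonyl behaves. No step beyond the scatter is therefore expected in this assay, and no direction is favoured. The expected step is a 1.0-fold lower number from compound 3 to compound 4 (0.00 log units; within the scatter). For compound 4 the estimated value is 20000 nM, with an expected range from 9000 nM to 45000 nM.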

Compound 4, concentration for 50% growth inhibition: 30300 nM
Beside the measured number, compound 4's estimate is 1.5-fold (0.18 log units) below it; the measured number falls inside the stated range.
By their numbers in this assay, from the lowest: compounds 2, 3, 4 and 1 (each within the scatter of the next, the first and the last beyond it).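

At this place on the aromatic ring, para to a large group, methoxycarbonyl in place of nitro gives a 1.5-fold higher number from compound 3 to compound 4 (0.18 log units; within the scatter) in this assay, so a second swap here stays within the scatter, yet methoxycarbonyl in place of fluoro gives a 2.1-fold higher number from compound 2 to compound 4 (0.31 log units; beyond the scatter), the first modest step measured between two groups at this place. Small steps can therefore add up across the three groups, even though neither fluoro to nitro nor nitro to methoxycarbonyl separates on its own. The contrast with the 2-bromophenyl compound also weakens: 4-(methoxycarbonyl)phenyl in place of 2-bromophenyl gives a 1.8-fold lower number from compound 1 to compound 4 (0.26 log units; within the scatter), which lies within the scatter, while the 4-fluorophenyl and 4-nitrophenyl swaps both lie beyond it, so a group at this place does not by itself set a compound apart from compound 1. No measured data on these compounds offer an explanation for these differences.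

Fluoro, nitro and methoxycarbonyl are too few to order the groups at this place by any shared feature, and how a free carboxylic acid, an amine or a longer ester chain would read here remains open. Compound 1 also leaves open whether its number follows from the bromo group itself or from where that group sits, as no compound shown separates the two.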